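A few compounds are considered here, and "the series" means these few. Any claim that something is new, unique, unknown or untested is made for them only; others in the source may bear on it.

In an ADME assay on RD cells (Homo sapiens) for cytotoxicity, read by MTT assay, with a stated time of 3 days (on this read-out higher numbers stand for lower toxicity in this test and lower numbers for higher toxicity in this test), compound 1 `CCC[C@@H](CCn1cncn1)c1ccc(Cl)cc1` gives 40.8 ug/mL and so lies within the usual scatter of compound 2 `CCC[C@@H](CCn1cncn1)c1ccc(C)cc1` at 74.1 ug/mL but far above compound 3 `CCCC[C@@H](CCn1cncn1)c1ccc(Cl)cc1Cl` at 1.9 ug/mL in this small set. Next comes compound 4 `Clc1ccc([C@H](CCn2cncn2)Cc2ccccc2)cc1` which keeps the core of compound 1 and changes one group: phenyl in place of ethyl on a saturated chain carbon, two bonds along the chain from an aromatic carbon that is, phenyl in place of ethyl on a saturated chain carbon, two bonds along the chain from an aromatic carbon.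

For the measured compounds named here, only one measured step involves a single change: a 1.8-fold higher number from compound 1 to compound 2 (0.26 log units; within the scatter) for methyl in place of chloro on an aromatic carbon. That change sits elsewhere in the molecule, so it says little about the new phenyl. Differing from compound 1 in more than one place, compound 3 at 1.9 ug/mL shows only that much lower numbers occur among these compounds. Going by the values given here, no measured compound carries the new group, so this forecast rests on thin evidence. A modest move towards a lower number, and so towards higher toxicity, is expected. The expected change is a 2.3-fold lower number from compound 1 to compound 4 (0.36 log units; beyond the scatter) and it may well stay inside the scatter. For compound 4 the estimate is 18 ug/mL with an expected range from 4 ug/mL to 60 ug/mL in this assay when it is measured.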

Compound 4, half-maximal cytotoxic concentration: 21.7 ug/mL
Beside the measured number, compound 4's estimate is 1.2-fold (0.08 log units) below it; the range from low to high includes it.
By their numbers in this assay, from the lowest: compound 3; then compounds 4, 1 and 2 (each within the scatter of the next, the first and the last beyond it).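

In this assay, phenyl in place of ethyl on a saturated chain carbon, two bonds along the chain from an aromatic carbon, gives a 1.9-fold lower number from compound 1 to compound 4 (0.27 log units; within the scatter) and so stays within the scatter. For the compounds shown here, this is the first view of this position, since the only earlier single step concerned a group on an aromatic carbon: here a group of 6 heavy atoms with an aromatic ring takes the place of a group of 2 heavy atoms with no ring, and no clear shift in the read-out follows. No measurement shown here offers an explanation for this result.

On these data alone, whether the same holds for other groups at this carbon, such as an amine, a carboxylic acid or a longer chain, remains open, and a single phenyl cannot show how far this position would accept change. As far as these compounds go, compound 3 differs from the other compounds in more than one place, so no single change can be read from it, and the part played by each of its differences also remains open.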